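Taking one chloro group off compound 3

This account rests on a few compounds, and the source may have more. Where it says the series, first, only, none or still open, it means among the compounds named here.

In a functional assay on U-937 cells (Homo sapiens) for cytotoxicity, read by CCK-8 assay, with a stated time of 72 h (on this read-out lower numbers stand for stronger inhibition and higher numbers for weaker inhibition), compound 3 `COc1ccccc1/C=c1\c(=O)[nH]/c(=C/c2cccc(Cl)c2Cl)c(=O)n1C` stands lowest of three numbers at 100 nM against compound 2 `C=CCn1c(=O)/c(=C\c2ccccc2Cl)[nH]c(=O)/c1=C\c1ccccc1OC` at 700 nM and compound 1 `COc1ccccc1/C=c1/[nH]c(=O)/c(=C\c2ccccc2OC)n(C)c1=O` at 1500 nM on this read-out. Compound 4 `COc1ccccc1/C=c1\c(=O)[nH]/c(=C/c2ccccc2Cl)c(=O)n1C` differs from compound 3 by one swap: hydrogen in place of chloro on an aromatic carbon turning 2,3-dichlorophenyl into 2-chlorophenyl. Going by the values given here, the one measured step at this place is a 15-fold lower number from compound 1 to compound 3 (1.18 log units; beyond the scatter) and it is large, yet no measured pair tests the chloro group alone. Compound 2 also carries 2-chlorophenyl and gives 700 nM with another group changed as well. A clear rise is therefore expected, with a 3.5-fold higher number from compound 3 to compound 4 (0.54 log units; beyond the scatter) as a step smaller than that large one. For compound 4 the estimate is 350 nM with 130 nM to 900 nM as its expected range.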

Compound 4, half-maximal inhibitory concentration: 100 nM
Beside the measured number, compound 4's estimate is 3.5-fold (0.54 log units) above it; the measured number lies below the stated range.
By their numbers in this assay, from the lowest: compounds 3 and 4 (each within the scatter of the next); then compound 2; then compound 1.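

Removing this chloro group gives no change at the digits printed from compound 3 to compound 4 (within the scatter) in this assay and so 2-chlorophenyl does as well as 2,3-dichlorophenyl on this read-out. Chloro in place of methoxy gives a 15-fold lower number from compound 1 to compound 4 (1.18 log units; beyond the scatter) as a single change, which the earlier compounds could not separate from the effect of a second chloro group. Hydrogen in place of vinyl on the saturated chain carbon bound to an aromatic nitrogen gives a 7.0-fold lower number from compound 2 to compound 4 (0.85 log units; beyond the scatter) as the first one-place reading of that chain. As far as these compounds go, whether an amine or a carboxylic acid in place of the remaining chloro group would keep this level stays open. No measurement shown here explains these steps.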